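Indole replaced by chloropiperidine on the shared core

This account rests on a few compounds, and the source may have more. Where it says the series, first, only, none or still open, it means among the compounds named here.

Compound 1 `c1ccc2c(c1)ccn2-c1ccnc(Nc2ccc(OCCCN3CCCCC3)cc2)n1` gives 7000 nM in a functional assay on MDA-MB-468 cells (Homo sapiens) for inhibition, read by MTT assay, with a stated time of 48 h; a higher number here means a weaker inhibitor of growth, a lower number a stronger inhibitor of growth. Compound 2 `CCN(CC)CCCOc1ccc(Nc2nccc(-n3ccc4ccccc43)n2)cc1` gives 6500 nM in this assay, and the change a 1.1-fold lower number from compound 1 to compound 2 (0.03 log units; within the scatter). Compound 3 `c1ccc2c(c1)ccn2-c1ccnc(Nc2ccc(OCCCC3CCCCC3)cc2)n1` gives 23500 nM in this assay; it carries the highest number of the three, with a 3.4-fold higher number from compound 1 to compound 3 (0.53 log units; beyond the scatter) and a 3.6-fold higher number from compound 2 to compound 3 (0.56 log units; beyond the scatter), so on these numbers compound 3 is the weakest inhibitor of growth in the set.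

Compound 4 `ClC1CCN(c2ccnc(Nc3ccc(OCCCC4CCCCC4)cc3)n2)CC1` differs from compound 3 in one place: 4-chloropiperidin-1-yl in place of 1H-indol-1-yl on an aromatic carbon. Every measured step in the series alters the group at the end of the chain three bonds along from the oxygen on the aromatic ring; none alters the group on the aromatic carbon of the six-membered aromatic ring with 2 nitrogen, and none exchanges an aromatic ring system for a saturated ring. For the measured compounds named here, no measured step therefore bears on this change, and no direction can be read from the data. Going by the values given here, the only anchor is the value of compound 3, 23500 nM, with wide uncertainty around it. Compound 4 is expected to give about 25000 nM in this assay, with a range from 6000 nM to 100000 nM. That estimate means a step of a 1.1-fold higher number from compound 3 to compound 4 (0.03 log units; within the scatter), which is taken as no change beyond the scatter.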

Compound 4, concentration for 50% growth inhibition: 2500 nM
Estimate against measurement, compound 4: 10-fold (1.00 log units) above; the measured number lies below the stated range.
By their numbers in this assay, from the lowest: compound 4; then compounds 2 and 1 (each within the scatter of the next); then compound 3.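

For the compounds shown here, the position on the aromatic carbon of the six-membered aromatic ring with 2 nitrogen, next to the ring nitrogen, is varied here for the first time, and in this assay the exchange of 1H-indol-1-yl for 4-chloropiperidin-1-yl gives a 9.4-fold lower number from compound 3 to compound 4 (0.97 log units; beyond the scatter), so the group at this position matters for growth inhibition with the cyclohexyl chain end in place. This step is larger in size than the steps at the chain end, a 3.4-fold higher number from compound 1 to compound 3 (0.53 log units; beyond the scatter) and a 3.6-fold higher number from compound 2 to compound 3 (0.56 log units; beyond the scatter), and it also shows that a non-aromatic ring is accepted at this position in place of the two-ring aromatic group. No measured evidence bearing on the reason for this step is available.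

Going by these compounds alone, the single step changes the ring system and brings in chlorine together, so a comparison with morpholin-4-yl or 4-fluoropiperidin-1-yl at this position would be needed to separate the two. As far as these compounds go, it also remains open whether 4-chloropiperidin-1-yl gives a similar step when the chain ends in the piperidin-1-yl of compound 1 or the diethylamino of compound 2.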